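Moving the Methyl on the Sulfonyl Phenyl Ring

The compounds below may be only part of what the source reports. "The series", "measured", "known", "first", "only" and "open" are said of these compounds alone.

Compound 3 `Cc1ccc(S(=O)(=O)NCc2ccc(CNC(=O)c3ccc(CNc4ncccn4)cc3)cc2)cc1` gives 100 nM in an assay on MDA-MB-231 cells for binding affinity to C-X-C chemokine receptor type 4 (Homo sapiens), read by microscopy, with stated times of 10 min and 30 min; a higher number here means that more compound is needed for the effect, a lower number that less compound is needed. Compound 1 `O=C(NCc1ccc(CNS(=O)(=O)c2ccc(Cl)cc2)cc1)c1ccc(CNc2ncccn2)cc1` gives 100 nM and compound 2 `O=C(NCc1ccc(CNS(=O)(=O)c2ccc(F)c(F)c2)cc1)c1ccc(CNc2ncccn2)cc1` gives 100 nM, so compound 3 sits level with both, the step of no change at the digits printed from compound 1 to compound 3 (within the scatter) and the step of no change at the digits printed from compound 2 to compound 3 (within the scatter) each lying within the scatter. Compound 4 `Cc1ccccc1S(=O)(=O)NCc1ccc(CNC(=O)c2ccc(CNc3ncccn3)cc2)cc1` differs from compound 3 in one place: 2-methylphenyl in place of 4-methylphenyl on a sulfonyl sulfur. Within the data shown here, no measured step moves a methyl from one place on that phenyl to another; the nearest precedents are no change at the digits printed from compound 1 to compound 2 (within the scatter), no change at the digits printed from compound 1 to compound 3 (within the scatter) and no change at the digits printed from compound 2 to compound 3 (within the scatter), all of which exchange the group on the sulfonyl phenyl with no effect beyond the scatter. On that basis the expected step is no change at the digits printed from compound 3 to compound 4 (within the scatter), none beyond the scatter. Compound 4 is therefore estimated at 100 nM, within a range from 50 nM to 250 nM.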

Compound 4, effective concentration (reported as EC, without a stated level of effect): 10 nM
The estimate for compound 4 lay 10-fold (1.00 log units) above the measured number, and the stated range ends above it.
By their numbers in this assay, from the lowest: compound 4; then compounds 1, 2 and 3 (each within the scatter of the next).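

Moving the methyl on the phenyl group gives a 10-fold lower number from compound 3 to compound 4 (1.00 log units; beyond the scatter) in this assay, so this position responds to where a methyl sits, a sensitivity that the exchanges among the earlier compounds did not reveal. The 2-methylphenyl group also stands apart from the 3,4-difluorophenyl and 4-chlorophenyl groups, with a 10-fold lower number from compound 2 to compound 4 (1.00 log units; beyond the scatter) and a 10-fold lower number from compound 1 to compound 4 (1.00 log units; beyond the scatter). Nothing given here accounts for these differences. Going by these compounds, whether the effect is specific to methyl remains open, and a 2-chlorophenyl or 2-methoxyphenyl group on the sulfonyl sulfur would address that. On these data alone, how a 3-methylphenyl group would compare also remains open.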